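Working notes: methoxy in place of hydrogen on compound 3

The compounds below may be only part of what the source reports. "The series", "measured", "known", "first", "only" and "open" are said of these compounds alone.

In a functional assay on HL-60 cells (Homo sapiens) for cytotoxicity, read by luminescence and CellTiter-Glo, with a stated time of 3 days (on this read-out lower numbers stand for stronger inhibition and higher numbers for weaker inhibition), compound 3 (`N#Cc1ccc(NC(=O)c2ccccc2O)cc1`) gives 4620 nM. Compound 2 (`Cc1cccc(O)c1C(=O)Nc1ccc(C#N)cc1`) gives 6860 nM, so these two compounds cannot be separated. Compound 1 (`N#Cc1ccc(NC(=O)c2c(O)cccc2F)cc1`) reads > 10000 nM, which is a limit of this assay and not a number.

Compound 4 (`COc1cccc(O)c1C(=O)Nc1ccc(C#N)cc1`) carries methoxy in place of hydrogen on an aromatic carbon of compound 3: methoxy in place of hydrogen on an aromatic carbon.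

Among the compounds with values here, two measured steps bear on this change, as both exchange hydrogen for another group at that carbon. a 1.5-fold lower number from compound 2 to compound 3 (0.17 log units; within the scatter) stays within the scatter, whereas an at least 2.1-fold lower number from compound 1 to compound 3 (0.33 log units; beyond the scatter) goes beyond it, though only as a floor set by a limit. Both point the same way: hydrogen gives the number no worse than the substituted compounds. A small move towards a higher number in this assay is therefore expected, probably not beyond the scatter.

The estimated step is a 1.5-fold higher number from compound 3 to compound 4 (0.18 log units; within the scatter).

For compound 4 the expected value is 7000 nM, with an estimated range of 3000 nM to 10000 nM.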

Compound 4, half-maximal inhibitory concentration: > 10000 nM
Compound 4: only a limit was reported; the forecaster's own chance of this, stated with the estimate: 20%; at least 1.4-fold (0.15 log units) between middle value and limit.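

In this assay methoxy on this aromatic carbon gives an at least 2.1-fold higher number from compound 3 to compound 4 (0.33 log units; beyond the scatter), so this group, like fluoro in compound 1, moves the number away from that of compound 3 by more than the scatter, though the size is only a floor. Against methyl the change gives an at least 1.4-fold higher number from compound 2 to compound 4 (0.16 log units; that floor lies within the scatter), a floor that does not separate the two groups, and the step between compound 1 and compound 4 cannot be read. Compound 4 reads as a limit and not as a number, so the full size of its steps stays unknown: the limit of > 10000 nM in this assay, at which 2 of the 4 values shown sit.

From the compounds shown here alone, whether an amine or a carboxylic acid at this carbon would give a lower number than compound 3, at 4620 nM, remains open. Also open, going by these compounds, is how an ethoxy group, with its longer chain, would compare with methoxy here.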